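One group exchanged on the shared core

A few compounds are considered here, and "the series" means these few. Any claim that something is new, unique, unknown or untested is made for them only; others in the source may bear on it.

Results so far in a functional assay on HCT-116 cells (Homo sapiens) for antiproliferative activity, read by CCK-8 assay, with a stated time of 72 h (on this read-out higher numbers stand for weaker inhibition and lower numbers for stronger inhibition), are these:
compound 1 `Cc1ccc(Nc2nc(Cl)nc3c2ncn3Cc2ccc(C(=O)Nc3ccccc3N)cc2)cc1` gives 580 nM
compound 2 `CCCCn1cnc2c(Nc3ccccc3)nc(NCOCc3ccc(C(=O)Nc4ccccc4N)cc3)nc21` gives 1190 nM

Compound 1 holds the lower of the two numbers, so it is the stronger inhibitor of the pair, and compound 2 sits higher by more than the usual scatter of repeated measurements. The next compound, compound 3 `CC1CCN(c2nc(Cl)nc3c2ncn3Cc2ccc(C(=O)Nc3ccccc3N)cc2)CC1`, keeps the core of compound 1 and differs from it in one place (4-methylpiperidin-1-yl in place of (4-methylphenyl)amino on an aromatic carbon) with 4-methylpiperidin-1-yl in place of (4-methylphenyl)amino on an aromatic carbon. A six-membered aromatic ring of carbon only thus gives way to a six-membered non-aromatic ring with a hetero atom. For the measured compounds named here, no two measured compounds differ in one place only, so the data offer no direct guide and any forecast here is uncertain. A moderate rise in the number, meaning weaker inhibition in this assay, is expected, though a change within the scatter remains possible. The estimated step is a 1.6-fold higher number from compound 1 to compound 3 (0.19 log units; within the scatter) as expected here. The estimated value for compound 3 is 900 nM with an expected range of 250 nM to 3000 nM in this assay overall.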

Compound 3, half-maximal inhibitory concentration: 950 nM
For compound 3 the middle estimate is 1.1-fold (0.02 log units) below the measured one; the measured number falls inside the stated range.
By their numbers in this assay, from the lowest: compounds 1, 3 and 2 (each within the scatter of the next, the first and the last beyond it).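

In this assay, for the compounds shown here, replacing (4-methylphenyl)amino with 4-methylpiperidin-1-yl on this aromatic carbon gives a 1.6-fold higher number from compound 1 to compound 3 (0.21 log units; within the scatter), the first direct comparison at this position. The exchange swaps a six-membered aromatic ring of carbon only for a six-membered non-aromatic ring with a hetero atom and removes the hydrogen-bond donor of the leaving group, yet the two numbers cannot be told apart, so for this pair neither the aromatic ring nor that donor is shown to matter in this assay. No measurement at hand bears on the reason for this result.

Because the ring and the donor change together, this pair cannot show what each contributes alone, and a single exchange says little about how far the position tolerates other groups. A (4-methylcyclohexyl)amino group would pair the non-aromatic ring with a retained amine hydrogen, while a morpholin-4-yl group would test a second hetero atom in the ring.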